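The source may report more compounds than this note shows. Statements on the series, on what has been measured and on what is new or still open speak of the compounds shown alone.

In a functional assay on MCF7 cells (Homo sapiens) for cytotoxicity, read by MTT assay, with a stated time of 48 h (on this read-out higher numbers stand for weaker inhibition and lower numbers for stronger inhibition), compound 1 (`Cc1n[nH]c2c1C(c1ccc(N(C)C)cc1)C(C(=O)NNC(N)=S)=C(N)N2`) gives 5210 nM as the lowest of three numbers, while compound 3 (`Cc1n[nH]c2c1C(c1ccc(N(C)C)cc1)C=C(N)N2`) gives 11200 nM and compound 2 (`Cc1n[nH]c2c1C(c1ccc(N(C)C)cc1)C(C(=O)n1ncc(C#N)c1N)=C(N)N2`) gives 62700 nM on the same read-out. Compound 4 (`Cc1n[nH]c2c1C(c1ccc(N(C)C)cc1)C(C(=O)N/N=C1/C(=O)Nc3ccccc31)=C(N)N2`) remains unmeasured and differs from compound 1 through a group of 11 heavy atoms (8 carbon, 2 nitrogen, 1 oxygen; one five-membered non-aromatic ring with 1 hetero atom, one six-membered aromatic ring of carbon only) in place of a group of 4 heavy atoms (1 carbon, 2 nitrogen, 1 sulfur; no ring), on an amide-type nitrogen alone. Among the compounds with values here, two measured steps bear on this change, a 12-fold higher number from compound 1 to compound 2 (1.08 log units; beyond the scatter) and a 2.1-fold higher number from compound 1 to compound 3 (0.33 log units; beyond the scatter) and both go to higher numbers, although neither makes the same replacement. A modest rise is therefore expected in this assay rather than a large one. The estimated step is a 1.7-fold higher number from compound 1 to compound 4 (0.24 log units; within the scatter) on this basis. Compound 4 is estimated at 9000 nM with an expected range from 2500 nM to 32000 nM in this measurement.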

Compound 4, half-maximal inhibitory concentration: 59100 nM
Compound 4: middle estimate off by 6.6-fold (0.82 log units), on the low side, and the stated range ends below it.
By their numbers in this assay, from the lowest: compound 1; then compound 3; then compounds 4 and 2 (each within the scatter of the next).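

In this assay, a change confined to the amide-type nitrogen, with the carbonyl kept, gives an 11-fold higher number from compound 1 to compound 4 (1.05 log units; beyond the scatter), so altering the group at this nitrogen alone is enough for a large step. Compound 2 at 62700 nM and compound 4 at 59100 nM lie within the scatter of each other, although their ring-bearing groups differ. No measurement here accounts for the step. The compounds shown leave open whether a small group such as acetyl or methyl at this nitrogen would stay close to compound 1.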